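Oral exposure notes on a two-compound series

A few compounds are considered here, and "the series" means these few. Any claim that something is new, unique, unknown or untested is made for them only; others in the source may bear on it.

Measured in an ADME assay on the whole organism for pharmacokinetics, with Mus musculus as the target, at a dose of 10 mg/kg by the oral route; a lower number here means less compound in the circulation, a higher number more compound in the circulation at the dose given:
- compound 1 `CC1=C(c2ccc(C#N)cc2)C(c2ccc(OC[C@H](C)N3CC[C@@H](C)C3)cc2)Oc2ccc(O)cc21`: 2000 ng.h/mL
- compound 2 `CC1=C(c2cccc(S(C)(=O)=O)c2)C(c2ccc(OC[C@H](C)N3CC[C@@H](C)C3)cc2)Oc2ccc(O)cc21`: "not determined" (no result reported)

Compound 2 has no single number to stand on, so compound 1 at 2000 ng.h/mL is the only anchor. Compound 3 `CC1=C(c2ccc(F)cc2)C(c2ccc(OC[C@H](C)N3CC[C@@H](C)C3)cc2)Oc2ccc(O)cc21` is still unmeasured. The change is 4-fluorophenyl in place of 3-(methylsulfonyl)phenyl on a double-bonded ring carbon. Among the measured compounds shown here, with no number for compound 2, no step from it can be sized in this assay. A result near compound 1 at 2000 ng.h/mL is expected, with no direction beyond the scatter. For compound 3 the expected value is 1800 ng.h/mL, with an estimated range of 600 ng.h/mL to 5000 ng.h/mL.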

Compound 3, area under the concentration-time curve: 2000 ng.h/mL
For compound 3 the middle estimate is 1.1-fold (0.05 log units) below the measured one, within the range that was stated.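

In this assay the series now has a readable step at this position: no change at the digits printed from compound 1 to compound 3 (within the scatter), with fluoro in place of cyano on an aromatic carbon. At this dose, the exposure readout does not separate these two groups. The step involving compound 2 cannot be read. No measurement shown gives a reason for this result.

Still open, from the compounds shown here alone, is whether an amine or a carboxylic acid on that aromatic carbon would leave the exposure unchanged. The effect of the 3-(methylsulfonyl)phenyl group also remains unsized.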